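This account rests on a few compounds, and the source may have more. Where it says the series, first, only, none or still open, it means among the compounds named here.

Of the compounds shown here, three sharing one core have been tested in a functional assay on BXPC-3 cells (Homo sapiens) for inhibition, read by MTT assay, with a stated time of 7 days; on this read-out lower numbers stand for stronger inhibition and higher numbers for weaker inhibition. Compound 1 `CCN(CC)S(=O)(=O)c1ccc(S(=O)(=O)N2CCC[C@@H](C(=O)NC3CN(S(C)(=O)=O)C3)C2)cc1` gives 7400 nM in this assay. Compound 2 `CCN(CC)C(=O)[C@@H]1CCCN(S(=O)(=O)c2ccc(S(=O)(=O)N(CC)CC)cc2)C1` gives 10500 nM in this assay, and compound 3 `CCN(CC)S(=O)(=O)c1ccc(S(=O)(=O)N2CCC[C@@H](c3cc(C)no3)C2)cc1` gives 7700 nM in this assay. Compound 3 thus stands second highest of the three numbers; its nearest neighbour is compound 1 and its furthest is compound 2, yet every gap among them lies within the scatter: a 1.4-fold higher number from compound 1 to compound 2 (0.15 log units; within the scatter), a 1.0-fold higher number from compound 1 to compound 3 (0.02 log units; within the scatter) and a 1.4-fold lower number from compound 2 to compound 3 (0.13 log units; within the scatter).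

Compound 4 `CCN(CC)S(=O)(=O)c1ccc(S(=O)(=O)N2CCC[C@@H](C(=O)NC)C2)cc1` is the next compound to be measured. It differs from compound 3 in one place: methylcarbamoyl in place of 3-methyl-1,2-oxazol-5-yl on a saturated ring carbon. Among the measured compounds shown here, the steps that bear on this are those that already varied the group on that saturated ring carbon. Replacing the (1-(methylsulfonyl)azetidin-3-yl)carbamoyl group or the diethylcarbamoyl group with the 3-methyl-1,2-oxazol-5-yl group left the numbers within the scatter, as did the exchange of one carbamoyl substituent for another in the step from compound 1 to compound 2. A change to methylcarbamoyl is therefore expected to give no step beyond the scatter in this assay, so that a 1.0-fold higher number from compound 3 to compound 4 (0.02 log units; within the scatter) is what is estimated. Compound 4 is expected to give about 8000 nM in this assay, with a range from 4000 nM to 16000 nM.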

Compound 4, half-maximal inhibitory concentration: 13800 nM
Compound 4: middle estimate off by 1.7-fold (0.24 log units), on the low side; the measured number falls inside the stated range.
By their numbers in this assay, from the lowest: compounds 1, 3, 2 and 4 (each within the scatter of the next).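

In this assay, replacing the 3-methyl-1,2-oxazol-5-yl group with methylcarbamoyl gives a 1.8-fold higher number from compound 3 to compound 4 (0.25 log units; within the scatter), so even a group with no ring and with 1 hydrogen-bond donor on this saturated ring carbon produces no step beyond the scatter. The steps to methyl on the amide-type nitrogen are a 1.3-fold higher number from compound 2 to compound 4 (0.12 log units; within the scatter) and a 1.9-fold higher number from compound 1 to compound 4 (0.27 log units; within the scatter) and both lie within the scatter. Methyl, the two ethyl groups of diethylcarbamoyl and 1-(methylsulfonyl)azetidin-3-yl cannot be told apart on this read-out. No measurement is available that would account for these numbers.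

On these data alone, the four compounds therefore give no sign that the group at this position matters for this read-out, and it remains open whether any group there can move the number beyond the scatter. A carboxylic acid, a primary amine or a longer alkyl chain on that ring carbon would test this, as would a bare ring carbon with no substituent at all.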